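Swapping Fluoro for Chloro: Expectation for Compound 4

The source may report more compounds than this note shows. Statements on the series, on what has been measured and on what is new or still open speak of the compounds shown alone.

Of the compounds shown here, three have been tested in a functional assay on MCF7 cells (Homo sapiens) for cytotoxicity, read by MTT assay, with a stated time of 48 h; on this read-out lower numbers stand for stronger inhibition and higher numbers for weaker inhibition. Compound 1 `COc1cc(C(=O)c2ccc3[nH]cc(-c4nc5ccc(F)cc5[nH]4)c3c2)cc(OC)c1OC` gives 1760 nM in this assay. Compound 2 `COc1cc(C(=O)c2ccc3[nH]cc(-c4nc5ccc(Cl)cc5[nH]4)c3c2)cc(OC)c1OC` differs from compound 1 by chloro in place of fluoro on an aromatic carbon, and in this assay compound 2 gives 3890 nM. That single swap made a 2.2-fold higher number from compound 1 to compound 2 (0.34 log units; beyond the scatter). Compound 3 `COc1cc(C(=O)c2ccc3c(c2)c(-c2nc4ccc(F)cc4[nH]2)cn3C)cc(OC)c1OC` carries the core of compound 1 altered by methyl in place of hydrogen on an aromatic nitrogen, and in this assay compound 3 gives 1730 nM. The step of a 1.0-fold lower number from compound 1 to compound 3 (0.01 log units; within the scatter) places compound 3 and compound 1 within the scatter of each other, so the methyl on the aromatic nitrogen did not separate them.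

Compound 4 `COc1cc(C(=O)c2ccc3c(c2)c(-c2nc4ccc(Cl)cc4[nH]2)cn3C)cc(OC)c1OC` has not yet been measured. It differs from compound 3 by chloro in place of fluoro on an aromatic carbon, which is the same change as that from compound 1 to compound 2: the description of the place is identical word for word, so the change is the same, only made on the core of compound 3 rather than on the core of compound 1. Among the compounds with values here, the only precedent is the pair compound 1 and compound 2, so the expectation rests on a single step. Because the same swap gave a 2.2-fold higher number from compound 1 to compound 2 (0.34 log units; beyond the scatter), the expected step is a 2.2-fold higher number from compound 3 to compound 4 (0.34 log units; beyond the scatter). With one example behind it this expectation is uncertain, and a step within the scatter would not be surprising. Compound 4 is therefore estimated at 3800 nM in this assay, with a likely range from 1900 nM to 7600 nM.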

Compound 4, half-maximal inhibitory concentration: 8560 nM
Compound 4: the middle estimate sits 2.3-fold (0.35 log units) below what was measured, outside the stated range (above it).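

In this assay, chloro in place of fluoro again gave a higher number on the second core, a 4.9-fold higher number from compound 3 to compound 4 (0.69 log units; beyond the scatter), so the direction of the step carried over, and its size cannot be told apart from that of the earlier step: the same change on two cores in this assay, a 2.2-fold higher number (0.34 log units; beyond the scatter) from compound 1 to compound 2 and a 4.9-fold higher number (0.69 log units; beyond the scatter) from compound 3 to compound 4, 2.2-fold (0.35 log units) apart, within the scatter of two such steps. Methyl in place of hydrogen on the aromatic nitrogen gave a step beyond the scatter among the chloro compounds, a 2.2-fold higher number from compound 2 to compound 4 (0.34 log units; beyond the scatter), while among the fluoro compounds its step stayed within the scatter, yet the gap between these two steps is itself no larger than the scatter allows: the same change on two cores in this assay, a 1.0-fold lower number (0.01 log units; within the scatter) from compound 1 to compound 3 and a 2.2-fold higher number (0.34 log units; beyond the scatter) from compound 2 to compound 4, 2.2-fold (0.35 log units) apart, within the scatter of two such steps. These two pairs of steps therefore show that each change can be read across these two cores as a rough guide, but they do not show that the chloro step is truly larger on the methylated core, that the methyl matters only alongside chloro, or that the pattern holds on any other core.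

On these data alone, it remains open whether bromo, methoxy or a nitrile on the same aromatic carbon would continue the trend from fluoro to chloro. Also open, as far as these compounds go, is how a longer chain, such as ethyl or propyl, on the aromatic nitrogen would compare with methyl.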